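Methylphenyl Variant on the Aromatic Nitrogen

The compounds below may be only part of what the source reports. "The series", "measured", "known", "first", "only" and "open" are said of these compounds alone.

Compound 1 `C/C(=C\CC/C(C)=C/CC[C@@H]1[C@@]2(C)CCC(=O)C(C)(C)[C@H]2CC[C@@]1(C)O)CC/C=C(\C)C(=O)OCc1cn(-c2ccccc2C(F)(F)F)nn1` carries a 2-(trifluoromethyl)phenyl on an aromatic nitrogen. In a functional assay on A549 cells (Homo sapiens) for antiproliferative activity, read by MTT assay, with a stated time of 48 h (on this read-out higher numbers stand for weaker inhibition and lower numbers for stronger inhibition), compound 1 reaches only a limit of the assay, > 150000 nM. Compound 2 `C/C(=C\CC/C(C)=C/CC[C@@H]1[C@@]2(C)CCC(=O)C(C)(C)[C@H]2CC[C@@]1(C)O)CC/C=C(\C)C(=O)OCc1cn(-c2ccc(F)cc2)nn1` also stops at a limit, with compound 2 giving > 150000 nM. Among the measured compounds shown here, compound 3 `C/C(=C\CC/C(C)=C/CC[C@@H]1[C@@]2(C)CCC(=O)C(C)(C)[C@H]2CC[C@@]1(C)O)CC/C=C(\C)C(=O)OCc1cn(C[C@@H]2O[C@H](n3ccc(=O)[nH]c3=O)C[C@H]2O)nn1` is the one member with a number, compound 3 showing 28100 nM. For the measured compounds named here, the only comparison between phenyl variants, a step that the two limits leave unreadable from compound 1 to compound 2, cannot be sized, since the limit of > 150000 nM in this assay, at which 2 of the 3 values shown sit, holds both members. Compound 4 `C/C(=C\CC/C(C)=C/CC[C@@H]1[C@@]2(C)CCC(=O)C(C)(C)[C@H]2CC[C@@]1(C)O)CC/C=C(\C)C(=O)OCc1cn(-c2ccc(C)cc2)nn1` makes the change (4-methylphenyl in place of 2-(trifluoromethyl)phenyl on an aromatic nitrogen). Going by the values given here, with no sized step to draw on and both phenyl analogues at the limit, compound 4 is expected to stay there as well, at about 150000 nM with a range of 40000 nM to 400000 nM. The expected step is a number no higher from compound 1 to compound 4 (the limit leaves the size open), most likely again reported only as a limit.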

Compound 4, half-maximal inhibitory concentration: > 150000 nM
Compound 4: only a limit was reported; the forecaster's own chance of this, stated with the estimate: 75%; the middle value sits exactly at the limit.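

No new step can be read among compound 1, compound 2 and compound 4, which all stop at one limit in this assay: the limit of > 150000 nM in this assay, at which 3 of the 4 values shown sit. As far as these compounds go, how far these phenyl variants differ from one another stays open.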